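The source may report more compounds than this note shows. Statements on the series, on what has been measured and on what is new or still open speak of the compounds shown alone.

In a functional assay on A549 cells (Homo sapiens) for cytotoxicity, read by MTT assay, with a stated time of 72 h (on this read-out lower numbers stand for stronger inhibition and higher numbers for weaker inhibition), compound 1 `CNC(=O)c1cc(Oc2ccc(C(=O)/C=C/c3ccco3)cc2)ccn1` has the entry "not determined" (no result reported). Compound 2 `CNC(=O)c1cc(Oc2ccc(C(=O)/C=C/c3ccc(Br)cc3)cc2)ccn1` gives > 50000 nM, which is a limit of the assay and not a number. Among the compounds with values here, compound 3 `CNC(=O)c1cc(Oc2ccc(C(=O)/C=C/c3ccc(F)cc3)cc2)ccn1` gives 18600 nM, the only actual number so far. Compound 4 `CNC(=O)c1cc(Oc2ccc(C(=O)/C=C/c3cccc(Cl)c3Cl)cc2)ccn1` has 2,3-dichlorophenyl in place of 4-fluorophenyl on a double-bonded chain carbon bound to a double-bonded chain carbon. Within the data shown here, only one measured change bears on this, fluoro in place of bromo on an aromatic carbon, which gave an at least 2.6-fold lower number from compound 2 to compound 3 (0.42 log units; beyond the scatter). This step is beyond the scatter, but it is a single pair with a different substitution and shows no general pattern. Since the fluoro compound 3 reads lower than the bromo compound 2, leaving 4-fluorophenyl for a chlorinated ring is expected to raise the number modestly in this assay. The expected step is a 1.5-fold higher number from compound 3 to compound 4 (0.18 log units; within the scatter). Compound 4 is estimated at 28000 nM, with an expected range of 10000 nM to 60000 nM.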

Compound 4, half-maximal inhibitory concentration: > 50000 nM
Compound 4: no number, only a limit; the forecaster's own chance of this, stated with the estimate: 30%; at least 1.7-fold (0.25 log units) between middle value and limit.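

In this assay, 2,3-dichlorophenyl in place of 4-fluorophenyl on a double-bonded chain carbon bound to a double-bonded chain carbon gives an at least 2.6-fold higher number from compound 3 to compound 4 (0.42 log units; beyond the scatter), a step beyond the scatter and the first one measured away from compound 3 to a chlorinated ring. Compound 4 gives a limit of the assay and not a number, and so does compound 2: the limit of > 50000 nM in this assay, at which 2 of the 4 values shown sit. Among these three compounds, which differ only in this ring, only the 4-fluorophenyl of compound 3 gives an actual number, and the step between compound 2 and compound 4 cannot be read.

From the compounds shown here alone, how far compound 2 and compound 4 lie from each other therefore stays open. Also open, going by these compounds, is whether a ring carrying a methoxy group or a dimethylamino group at this place would read lower than compound 3.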